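Phenyl to thiophen-2-yl on the amide-linked chain

A few compounds are considered here, and "the series" means these few. Any claim that something is new, unique, unknown or untested is made for them only; others in the source may bear on it.

Compounds measured so far:
compound 1, `COc1cc(-c2cc(C(=O)O)c3ccccc3n2)ccc1OCC(=O)Nc1ccc(C)cc1`, in a physicochemical assay for lipophilicity, using the shake flask method, in phosphate buffer, measured as octanol-water partition, at pH 7.4 (on this read-out lower numbers stand for lower lipophilicity and higher numbers for higher lipophilicity), compound 1 gives 1.2;
compound 2, `COc1cc(-c2cc(C(=O)O)c3ccccc3n2)ccc1OCC(=O)NCc1ccccc1`, in this assay compound 2 gives 0.4.

For the measured compounds named here, of the two numbers, compound 2 stands lowest; its nearest neighbour is compound 1, the only other measured compound, and the single measured step is a number 0.80 log units lower from compound 1 to compound 2 (beyond the scatter).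

Compound 3, `COc1cc(-c2cc(C(=O)O)c3ccccc3n2)ccc1OCC(=O)NCc1cccs1`, carries the change (thiophen-2-yl in place of phenyl on a saturated chain carbon bound to an amide-type nitrogen). Going by the values given here, the one measured step concerns a different exchange, benzyl in place of 4-methylphenyl, so no measured step bears directly on this change. In the absence of a matching precedent, compound 3 is expected to sit close to compound 2, with a small step of a number 0.20 log units lower from compound 2 to compound 3 (within the scatter) in this assay that may not exceed the usual scatter. The estimate for compound 3 is 0.2, within a range from -0.3 to 0.7.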

Compound 3, distribution coefficient: 0
Compound 3: the middle estimate sits 0.20 log units above what was measured; the measured number falls inside the stated range.
By their numbers in this assay, from the lowest: compound 3; then compound 2; then compound 1.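

In this assay, thiophen-2-yl in place of phenyl on a saturated chain carbon bound to an amide-type nitrogen gives a number 0.40 log units lower from compound 2 to compound 3 (beyond the scatter) and so moves the read-out at this place, which the earlier exchange of benzyl for 4-methylphenyl could not show. Set against the 4-methylphenyl compound, (thiophen-2-yl)methyl on the amide-type nitrogen gives a larger step (a number 1.20 log units lower from compound 1 to compound 3 (beyond the scatter)) in the same direction as the step to benzyl (a number 0.80 log units lower from compound 1 to compound 2 (beyond the scatter)). No measurement at hand accounts for either step.

On these data alone, it remains open whether other rings at this place, such as furan-2-yl or pyridin-2-yl, would move the number in the same direction. Also open, as far as these compounds go, is what a longer chain carrying the thiophen-2-yl ring, or thiophen-3-yl in its stead, would give.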